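Swapping a Triazole for a Pyrimidine on Two Related Cores

This account rests on a few compounds, and the source may have more. Where it says the series, first, only, none or still open, it means among the compounds named here.

Measured so far:
Compound 1, `CCN(C(=O)c1cc(C)ccc1-n1nccn1)[C@@H](C)Cn1nnc(-c2ccc(F)cc2)n1`, gives 0.82 nM in a functional assay on cells for antagonist activity at Orexin/Hypocretin receptor type 1 (Homo sapiens), read by fluorescence and calcium flux, with a stated time of 30 min; a higher number here means a weaker inhibitor, a lower number a stronger inhibitor.
Compound 2, `CCN(C(=O)c1cc(C)ccc1-c1ncccn1)[C@@H](C)Cn1nnc(-c2ccc(F)cc2)n1`, gives 1.81 nM in this assay.
Compound 3, `CCN(C(=O)c1nc(C)ccc1-n1nccn1)[C@@H](C)Cn1nnc(-c2ccc(F)cc2)n1`, gives 1.84 nM in this assay.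

Compound 4, `CCN(C(=O)c1nc(C)ccc1-c1ncccn1)[C@@H](C)Cn1nnc(-c2ccc(F)cc2)n1`, has not been measured. It relates to compound 3 as compound 2 relates to compound 1. Going from compound 1 to compound 2 the change is pyrimidin-2-yl in place of 2H-1,2,3-triazol-2-yl on an aromatic carbon, and it brought a 2.2-fold higher number from compound 1 to compound 2 (0.34 log units; beyond the scatter). Going from compound 3 to compound 4 the change is pyrimidin-2-yl in place of 2H-1,2,3-triazol-2-yl on an aromatic carbon. This is the same kind of change, not the same change: in compound 1 it sits on a six-membered aromatic ring of carbon only, whereas in compound 3 it sits on a six-membered aromatic ring with 1 nitrogen, two atoms from the ring nitrogen. How the two cores themselves differ is not broken down here. Compound 3 and compound 2 give values that fall within the usual scatter of each other.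

Among the measured compounds shown here, with only one measured example of this swap, the expectation for compound 4 is that the step of a 2.2-fold higher number from compound 3 to compound 4 (0.34 log units; beyond the scatter) will be of similar size, because the measured step of a 2.2-fold higher number from compound 1 to compound 2 (0.34 log units; beyond the scatter) is the only guide available. Compound 4 is therefore estimated at 4 nM in this assay, expected to fall between 2 nM and 8 nM.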

Compound 4, half-maximal inhibitory concentration: 6.15 nM
The estimate for compound 4 lay 1.5-fold (0.19 log units) below the measured number; measured number inside the range.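

Replacing the 2H-1,2,3-triazol-2-yl with pyrimidin-2-yl on the core of compound 3 again weakens inhibition in this assay, giving a 3.3-fold higher number from compound 3 to compound 4 (0.52 log units; beyond the scatter). The change therefore acts in the same direction on both cores, and the two steps cannot be told apart in size: the same change on two cores in this assay, a 2.2-fold higher number (0.34 log units; beyond the scatter) from compound 1 to compound 2 and a 3.3-fold higher number (0.52 log units; beyond the scatter) from compound 3 to compound 4, 1.5-fold (0.18 log units) apart, within the scatter of two such steps. Two pairs of compounds cannot show that the swap would behave the same way on any other core, and they do not explain why the pyrimidin-2-yl compounds give the higher numbers.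

On these data alone, it remains open whether a plain phenyl ring or a pyrazol-1-yl group in the same place would give numbers closer to those of the triazole compounds or the pyrimidine compounds. The compounds shown also all keep the same ethyl group on the amide nitrogen and the same 4-fluorophenyl tetrazole, so whether the step keeps its size with a different group at either place is also unknown.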